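The source may hold more compounds than are shown below. What is called first, only, known or untested is meant among the compounds shown, and "the series" means these compounds.

Within the data shown here, in a functional assay on the whole organism for agonist activity, with Mus musculus as the target (a higher number here means that more compound is needed for the effect, a lower number that less compound is needed), compound 2 `CC(=O)N(C)CC#CCn1ccnc1` gives 1.4 mg/kg as the only actual number in this small set. Compound 1 `CC(=O)NCC#CCn1ccnc1` reaches only a limit, at > 100 mg/kg in this series. Compound 3 `CC(=O)N(C)CC#CCn1cncc1C` likewise reaches only a limit, at > 100 mg/kg in the same read-out.

Among the measured compounds shown here, two measured steps bear on compound 2. Methyl in place of hydrogen on an amide-type nitrogen gives an at least 71-fold lower number from compound 1 to compound 2 (1.85 log units; beyond the scatter) and methyl in place of hydrogen on an aromatic carbon gives an at least 71-fold higher number from compound 2 to compound 3 (1.85 log units; beyond the scatter) in this series. Both are large, so a single small change can matter greatly here.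

Compound 4 `CN(C)C(=O)N(C)CC#CCn1ccnc1` is still unmeasured. For the measured compounds named here, it carries dimethylamino in place of methyl on a carbonyl carbon as its one difference from compound 2, dimethylamino in place of methyl on a carbonyl carbon. Neither measured step changes that place, so they guide its size only loosely. Going by the values given here, the one change away from compound 2 that has been measured gave an at least 71-fold higher number from compound 2 to compound 3 (1.85 log units; beyond the scatter) as its result, so a higher number is expected in this assay, though a smaller move. The expected change is a 5.7-fold higher number from compound 2 to compound 4 (0.76 log units; beyond the scatter) in this estimate. For compound 4 the estimated value is 8 mg/kg with an expected range from 1.5 mg/kg to 60 mg/kg in this assay.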

Compound 4, dose for half-maximal effect: > 100 mg/kg
Compound 4 ended at the assay's limit (the forecaster's own chance of this, stated with the estimate: 30%); middle value at least 12-fold (1.09 log units) from the limit.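

Until now only the amide-type nitrogen and the aromatic carbon had been seen to matter, but the carbonyl carbon now joins them: dimethylamino in place of methyl at this place, the change from acetyl to dimethylcarbamoyl, gives an at least 71-fold higher number from compound 2 to compound 4 (1.85 log units; beyond the scatter). In this assay compound 4 gives > 100 mg/kg, which is a limit and not a number. The true size of this step therefore stays unknown, and the series offers very little resolution on the high side: the limit of > 100 mg/kg in this assay, at which 3 of the 4 values shown sit.

As far as these compounds go, whether any group other than methyl on this carbonyl carbon keeps a measurable number stays open, as neither ethyl nor methoxy appears there. The compounds also leave open whether a plain amino group at the same place would end at the limit too, or whether only the full dimethylamino group does so.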